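Working notes on lipophilicity across a biaryl series

The source may hold more compounds than are shown below. What is called first, only, known or untested is meant among the compounds shown, and "the series" means these compounds.

Compound 1, `CCOc1ccccc1-c1ccc(-c2nc3cnccc3c(N[C@H](CC)C(N)=O)c2C#N)cc1`, in a physicochemical assay for lipophilicity, read by HPLC, at pH 7.5 (on this read-out higher numbers stand for higher lipophilicity and lower numbers for lower lipophilicity), gives 3.
Compound 2, `CC[C@@H](Nc1c(C#N)c(-c2ccc(-c3ncccc3C)cc2)nc2cnccc12)C(N)=O`, in this assay gives 2.
Compound 3, `CC[C@@H](Nc1c(C#N)c(-c2ccc(-c3ccccc3COC)cc2)nc2cnccc12)C(N)=O`, in this assay gives 2.6.

Compound 3 stands second highest of the three values: a number 0.40 log units lower from compound 1 to compound 3 (beyond the scatter) places it under compound 1, and a number 0.60 log units higher from compound 2 to compound 3 (beyond the scatter) places it over compound 2. Compound 4, `CC[C@@H](Nc1c(C#N)c(-c2ccc(-c3cccc(C)c3F)cc2)nc2cnccc12)C(N)=O`, is not yet measured. The change: 2-fluoro-3-methylphenyl in place of 2-(methoxymethyl)phenyl on an aromatic carbon. For the measured compounds named here, no measured step brings in a phenyl bearing both a fluorine and a methyl; the steps that bear on it are a number 0.40 log units lower from compound 1 to compound 3 (beyond the scatter), where the methoxymethyl group entered, and a number 0.60 log units higher from compound 2 to compound 3 (beyond the scatter), where it replaced a pyridyl ring, both modest. With the methoxymethyl group leaving, for compound 4 a modest rise is expected, a number 0.70 log units higher from compound 3 to compound 4 (beyond the scatter). Compound 4 is therefore estimated at 3.3, within 2.9 to 3.7.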

Compound 4, distribution coefficient: 3
Compound 4: middle estimate off by 0.30 log units, on the high side; low and high end bracket the measured number.
By their numbers in this assay, from the lowest: compound 2; then compound 3; then compounds 1 and 4 (each within the scatter of the next).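

In this assay, at this aromatic carbon para to a large group, 2-fluoro-3-methylphenyl in place of 2-(methoxymethyl)phenyl gives a number 0.40 log units higher from compound 3 to compound 4 (beyond the scatter), and in place of 3-methylpyridin-2-yl it gives a number 1.00 log units higher from compound 2 to compound 4 (beyond the scatter). For the compounds shown here, in place of 2-ethoxyphenyl it gives no change at the digits printed from compound 1 to compound 4 (within the scatter), the first pair of different groups here that reads alike. Nothing measured speaks to the cause of these values.

The compounds shown carry fluorine and methyl on a phenyl ring only together, leaving their separate shares open. Also open, going by these compounds, is how a phenyl ring bearing an amine or a carboxylic acid would read here.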